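Swapping cyclopentyl for tert-butoxy on a carbonyl carbon

The source may hold more compounds than are shown below. What is called first, only, known or untested is meant among the compounds shown, and "the series" means these compounds.

Of the compounds shown here, three built on a shared core have been measured in a functional assay on SU-DHL-6 cells (Homo sapiens) for antiproliferative activity, read by CCK-8 assay, with a stated time of 72 h; a higher number here means a weaker inhibitor, a lower number a stronger inhibitor. Compound 3 `COc1ncc(-c2ccc3ncnc(N[C@H]4CCN(C(=O)C5CCCC5)C4)c3c2)cc1NS(C)(=O)=O` gives 770 nM. Compound 2 `COc1ncc(-c2ccc3ncnc(NCCN4CCCCC4)c3c2)cc1NS(=O)(=O)C1CC1` gives 410 nM, and these two values lie within the scatter of each other. Compound 1 `COc1ncc(-c2ccc3ncnc(N(C)CCN(C)C)c3c2)cc1NS(C)(=O)=O` gives 1700 nM, so compound 3 is the stronger inhibitor of that pair, by a margin beyond the scatter.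

Compound 4 `COc1ncc(-c2ccc3ncnc(N[C@H]4CCN(C(=O)OC(C)(C)C)C4)c3c2)cc1NS(C)(=O)=O` has not yet been measured. It carries tert-butoxy in place of cyclopentyl on a carbonyl carbon, turning cyclopentylcarbonyl into tert-butoxycarbonyl: tert-butoxy in place of cyclopentyl on a carbonyl carbon. For the measured compounds named here, no two measured compounds differ in only one place, so the data do not show directly how large such a change can be. The expectation therefore starts from compound 3 at 770 nM, with no step beyond the scatter foreseen in this assay in either direction. The estimated change a 1.1-fold lower number from compound 3 to compound 4 (0.04 log units; within the scatter) is expected to stay within the scatter. For compound 4 the expected value is 700 nM, with an estimated range of 250 nM to 2000 nM.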

Compound 4, half-maximal inhibitory concentration: 170 nM
The estimate for compound 4 lay 4.1-fold (0.61 log units) above the measured number; measured number outside the range, below it.
By their numbers in this assay, from the lowest: compound 4; then compounds 2 and 3 (each within the scatter of the next); then compound 1.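

In this assay, for the compounds shown here, turning cyclopentylcarbonyl into tert-butoxycarbonyl gives a 4.5-fold lower number from compound 3 to compound 4 (0.66 log units; beyond the scatter) and is the first change in this set that can be read in one place. The position is therefore sensitive to this swap, even though both groups count the same number of heavy atoms; what differs is that a five-membered carbon ring leaves, while an oxygen with one hydrogen-bond acceptor enters. Nothing measured here accounts for the step.

The pair cannot separate the loss of the ring from the arrival of the oxygen: cyclopentyloxy, which keeps both, and neopentyl, which has neither, would be needed on the same carbonyl carbon. From the compounds shown here alone, how a smaller methoxy group or an amine at this carbonyl would read also remains open.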